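A second methoxy on compound 2

The compounds below may be only part of what the source reports. "The series", "measured", "known", "first", "only" and "open" are said of these compounds alone.

Measured so far:
- compound 1 `Cc1cccn2cc(-c3nnc(-c4ccc(Br)cc4)o3)nc12`: 34700 nM
- compound 2 `COc1ccc(-c2nnc(-c3cn4cccc(C)c4n3)o2)cc1`: 12800 nM

Both compounds were read in a functional assay on A549 cells (Homo sapiens) for antiproliferative activity, read by MTT assay, with a stated time of 48 h; a higher number here means a weaker inhibitor, a lower number a stronger inhibitor. Of the two, compound 2 holds the lower number, so it is the stronger inhibitor here, though both values remain high on this scale.

The next compound is compound 3 `COc1ccc(-c2nnc(-c3cn4cccc(C)c4n3)o2)cc1OC`, which differs from compound 2 by methoxy in place of hydrogen on an aromatic carbon. This is methoxy in place of hydrogen on an aromatic carbon, ortho to a methoxy group and meta to a large group.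

Among the measured compounds shown here, only one measured step bears on this change: a 2.7-fold lower number from compound 1 to compound 2 (0.43 log units; beyond the scatter). It is modest, and it replaced bromo with methoxy, so it offers only indirect guidance on adding a further methoxy in place of hydrogen. On this single precedent, a small move toward a lower number is expected in this assay, and it may well stay within the scatter. The expected change is a 1.3-fold lower number from compound 2 to compound 3 (0.13 log units; within the scatter). For compound 3 the estimate is 9500 nM, with an expected range of 4000 nM to 22000 nM.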

Compound 3, half-maximal inhibitory concentration: 10900 nM
Beside the measured number, compound 3's estimate is 1.1-fold (0.06 log units) below it; measured number inside the range.
By their numbers in this assay, from the lowest: compounds 3 and 2 (each within the scatter of the next); then compound 1.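

In this assay, the new step is a 1.2-fold lower number from compound 2 to compound 3 (0.07 log units; within the scatter), so a methoxy ortho to a methoxy group and meta to a large group gives no difference that can be read beyond the scatter. Among the compounds shown here, the earlier step, a 2.7-fold lower number from compound 1 to compound 2 (0.43 log units; beyond the scatter), replaced one substituent with another and lay beyond the scatter, whereas this is the first reading of a methoxy in place of hydrogen on that six-membered aromatic ring. For the compounds shown here, with only this one step, the notes can say that the added methoxy is tolerated in this read-out, but nothing measured here explains that outcome.

Still open, on these data alone, is whether a different group at this place, such as a hydroxyl, an amine, a carboxylic acid or a longer chain like ethoxy, would move the number beyond the scatter. Also open, as far as these compounds go, is whether the same methoxy in place of hydrogen would read alike with bromo rather than the first methoxy on the ring, and whether the methyl group on the shared core matters at all.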